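One ring for another on the chain of compound 3

The source may hold more compounds than are shown below. What is called first, only, known or untested is meant among the compounds shown, and "the series" means these compounds.

Three compounds share one core and differ only in the chain hung from it. Compound 1 `CC/C=C/C(=O)Nc1cc2c(N3CCCc4ccccc43)ncnc2cc1OC` gives 5030 nM in a functional assay on A549 cells (Homo sapiens) for antiproliferative activity, read by MTT assay, with a stated time of 72 h; on this read-out lower numbers stand for stronger inhibition and higher numbers for weaker inhibition. Compound 2 `CCC/C=C/C(=O)Nc1cc2c(N3CCCc4ccccc43)ncnc2cc1OC` gives 1800 nM in this assay. That is a 2.8-fold lower number from compound 1 to compound 2 (0.45 log units; beyond the scatter). Compound 3 `COc1cc2ncnc(N3CCCc4ccccc43)c2cc1NC(=O)/C=C/CN1CCCC1` gives 2230 nM in this assay, the second highest of the three numbers: close to compound 2 and further from compound 1. The step from compound 1 to compound 3 is a 2.3-fold lower number from compound 1 to compound 3 (0.35 log units; beyond the scatter). The step from compound 2 to compound 3 is a 1.2-fold higher number from compound 2 to compound 3 (0.09 log units; within the scatter), so a pyrrolidin-1-yl and an ethyl at that spot behave alike here.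

Compound 4 `COc1cc2ncnc(N3CCCc4ccccc43)c2cc1NC(=O)/C=C/CN1CCN(C)CC1` carries one change against compound 3: 4-methylpiperazin-1-yl in place of pyrrolidin-1-yl on a saturated chain carbon bound to a double-bonded chain carbon. Both measured steps that touch this position show that replacing a small group by pyrrolidin-1-yl moved the number only modestly, and that the ring itself was no different from a plain chain end. A second ring of similar kind is therefore expected to leave compound 4 roughly where compound 3 sits, with no step beyond the scatter. The expected change is a 1.1-fold lower number from compound 3 to compound 4 (0.05 log units; within the scatter). Compound 4 is estimated at 2000 nM, within 800 nM to 5000 nM.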

Compound 4, half-maximal inhibitory concentration: 7830 nM
Estimate against measurement, compound 4: 3.9-fold (0.59 log units) below; measured number above the stated range.
By their numbers in this assay, from the lowest: compounds 2 and 3 (each within the scatter of the next); then compounds 1 and 4 (each within the scatter of the next).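

In this assay, among the compounds shown here, the change to 4-methylpiperazin-1-yl gives a 3.5-fold higher number from compound 3 to compound 4 (0.55 log units; beyond the scatter), the first step at this position beyond the scatter towards a higher number, so the two rings are not interchangeable here. Against the ethyl end, the same ring gives a 4.4-fold higher number from compound 2 to compound 4 (0.64 log units; beyond the scatter), the largest step in this small set, while against the methyl end it gives a 1.6-fold higher number from compound 1 to compound 4 (0.19 log units; within the scatter), which lies within the scatter, so the lower number that pyrrolidin-1-yl brought over methyl does not carry over to every ring. No measurement at hand accounts for the difference between the two rings.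

This one change replaces a five-membered ring with a six-membered one and also adds a second ring nitrogen and a methyl, and the compounds shown do not pull these apart. A piperidin-1-yl or morpholin-4-yl ring on the same saturated chain carbon would help show whether the higher number follows ring size or the second ring hetero atom, and a dimethylamino group would show how an open-chain amine compares with both rings.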